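A few compounds are considered here, and "the series" means these few. Any claim that something is new, unique, unknown or untested is made for them only; others in the source may bear on it.

Measured compounds in a functional assay on the whole organism with Amphibalanus amphitrite as the target; on this read-out higher numbers stand for an effect only at larger amounts of compound and lower numbers for an effect already at smaller amounts:
- compound 1, `C#C/C=C\CCCC/C=C\C#CC#CCCCC#CC#C[C@H](COS(=O)(=O)O)OS(=O)(=O)O`, gives 0.13 ug/mL
- compound 2, `C#C/C=C\CCCC(O)/C=C/C#CC#CCCCC#CC#CC(O)CO`, gives 0.13 ug/mL
- compound 3, `C#C/C=C/C(O)CCC/C=C\C#CC#CCCCC#CC#CC(O)CO`, gives 1.3 ug/mL

Compound 3 stands highest of the three numbers in this assay. Compound 1 and compound 2 each give a lower number, and both gaps lie beyond the scatter, so compound 3 is the weakest of the measured set. For the measured compounds named here, no pair of measured compounds differs in only one place, so no single measured step is available to lean on.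

Compound 4, `C#C/C=C\C(O)CCC/C=C\C#CC#CCCCC#CC#CC(O)CO`, is the next member. Relative to compound 3 the change is: the two compounds have the same atoms and bonds; at least one stereo element is drawn with a configuration in one of them and without one in the other: 1 of 4 stereo elements differ; a double bond is drawn E in compound 3 and Z in compound 4. All other stereo elements and the whole skeleton are kept.

Compound 1 and compound 2 both carry the Z geometry at this double bond and both give lower numbers than compound 3, though each also differs from compound 3 elsewhere, so this is only a loose pointer. The step from compound 3 to compound 4 in this assay is expected to run toward a lower number, most likely of moderate size, a 2.6-fold lower number from compound 3 to compound 4 (0.41 log units; beyond the scatter). Compound 4 is therefore estimated at 0.5 ug/mL in this assay, with a range from 0.15 ug/mL to 1.5 ug/mL.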

Compound 4, concentration for half-maximal effect: 0.13 ug/mL
For compound 4 the middle estimate is 3.8-fold (0.59 log units) above the measured one; measured number outside the range, below it.
By their numbers in this assay, from the lowest: compounds 1, 2 and 4 (each within the scatter of the next); then compound 3.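

The series now has its first comparison at a single place: in this assay, changing only the geometry at this double bond, with the skeleton and all other stereo elements kept, gives a 10-fold lower number from compound 3 to compound 4 (1.00 log units; beyond the scatter). The earlier compounds shown here each differed from one another in more than one place, so they could not show that this geometry alone can shift the number beyond the scatter. The reading remains modest, and one point limits it: the fact that one of compounds 3 and 4 is drawn with a defined configuration and the other without, at the place where they differ

Still open, as far as these compounds go, is whether the same change in geometry has a similar effect in a compound carrying the sulfate groups of compound 1. Also open, from the compounds shown here alone, is how this double-bond geometry would read with an acetate ester or a carboxylic acid in place of the hydroxyl groups.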